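Methylsulfonyl in place of (cyanomethyl)carbonyl on the shared core

The compounds below may be only part of what the source reports. "The series", "measured", "known", "first", "only" and "open" are said of these compounds alone.

Among the measured compounds shown here, only two compounds with this core have numbers so far in an ADME assay on MDCK cells (Canis lupus familiaris) for cytotoxicity, with a stated time of 48 h (on this read-out lower numbers stand for higher toxicity in this test and higher numbers for lower toxicity in this test), for comparison. For the measured compounds named here, compound 2 (`C=C(C(=O)OC)[C@@H]1CC[C@H](C)[C@H]2C(=C(C)C(=O)[C@H]2NC(=O)CC#N)C1`) stands highest with 1450 uM while compound 1 (`C=C(C(=O)OC)[C@@H]1CC[C@H](C)[C@H]2C(=C(C)C(=O)[C@H]2NC(=O)c2ccccc2)C1`) gives 84.3 uM as the only other number. Compound 3 (`C=C(C(=O)OC)[C@@H]1CC[C@H](C)[C@H]2C(=C(C)C(=O)[C@H]2NS(C)(=O)=O)C1`) is still unmeasured. It carries methylsulfonyl in place of (cyanomethyl)carbonyl on an amine nitrogen. Going by the values given here, one measured step bears on this change (a 17-fold higher number from compound 1 to compound 2 (1.24 log units; beyond the scatter)). That step, with cyanomethyl in place of phenyl on a carbonyl carbon, was large and beyond the scatter, so this part of the molecule can matter a great deal. However, it kept the carbonyl that compound 3 gives up, so it offers no firm direction here. With compound 2 at the top of just two numbers, a small drop within the scatter seems the likeliest outcome, though a larger move cannot be ruled out. The expected change is modest (a 1.8-fold lower number from compound 2 to compound 3 (0.26 log units; within the scatter)). Compound 3 is estimated at 800 uM as a central value, with an expected range from 250 uM to 2500 uM in a real measurement.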

Compound 3, half-maximal toxic concentration: 226 uM
For compound 3 the middle estimate is 3.5-fold (0.55 log units) above the measured one, and the stated range ends above it.
By their numbers in this assay, from the lowest: compound 1; then compound 3; then compound 2.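

Replacing the (cyanomethyl)carbonyl on the amine nitrogen with methylsulfonyl lowers the number in this assay (a 6.4-fold lower number from compound 2 to compound 3 (0.81 log units; beyond the scatter)), so exchanging the carbonyl link itself for a sulfonyl link can also shift this read-out, not only changing what sits on the carbonyl carbon. Methylsulfonyl nevertheless stands above benzoyl at the same nitrogen (a 2.7-fold higher number from compound 1 to compound 3 (0.43 log units; beyond the scatter)), which places compound 3 between the other two, with each of its steps beyond the usual scatter and the three groups in a clear order. Nothing available here accounts for this order, so the numbers describe what happens in this test without explaining it.

Among the compounds shown here, with only three groups at this nitrogen, it remains open how much of the spread comes from the type of link, carbonyl or sulfonyl, and how much from the group attached to that link. An acetyl group would put the methyl of compound 3 on a carbonyl, and a phenylsulfonyl group would put the phenyl of compound 1 on a sulfonyl, so this pair could begin to separate those two contributions.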